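The source may hold more compounds than are shown below. What is called first, only, known or untested is meant among the compounds shown, and "the series" means these compounds.

Compound 1, `Cn1nc(N)c2c(=O)[nH]c(-c3ccccc3)cc21`, is tested in an assay on isolated protein for inhibition of RAC-beta serine/threonine-protein kinase (Homo sapiens), read by mobility shift assay, tested at 30 uM (a higher number here means more inhibition at the concentration tested (going by the name of the read-out), a lower number less inhibition), where compound 1 gives 4%. For the measured compounds named here, the only other measured compound, compound 2, `Cn1nc(N)c2c(=O)[nH]c(-c3ccccn3)cc21`, gives 10% in this assay, and the step of a number 6 percentage points higher from compound 1 to compound 2 (within the scatter) lies within the scatter, so the two numbers cannot be told apart. Compound 3, `CC(=O)Nc1nn(C)c2cc(-c3ccccc3)[nH]c(=O)c12`, differs from compound 1 by acetyl in place of hydrogen on a nitrogen on an aromatic ring. Going by the values given here, no measured step touches this nitrogen; the one step known, a number 6 percentage points higher from compound 1 to compound 2 (within the scatter), changes another part of the molecule and stays within the scatter. Compound 3 is therefore expected near compound 1, with an estimated step of a number 1 percentage points higher from compound 1 to compound 3 (within the scatter). The estimate for compound 3 is 5%, expected between -5% and 20%.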

Compound 3, a percentage reported as inhibition, at one concentration (the size of the read-out at that concentration, not a potency): 40%
Compound 3: the middle estimate sits 35 percentage points below what was measured; measured number outside the range, above it.
By their numbers in this assay, from the lowest: compounds 1 and 2 (each within the scatter of the next); then compound 3.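

In this assay, amino to acetamido on this nitrogen gives a number 36 percentage points higher from compound 1 to compound 3 (beyond the scatter). This nitrogen is therefore a place where a single change moves the number beyond the scatter, which the earlier pyridin-2-yl swap elsewhere on the molecule did not show. No measurement here explains the rise.

Still open, going by these compounds, is whether the rise needs acetyl itself, or whether a longer acyl chain such as propanoyl, a simple methyl or a urea on this nitrogen would also give it. On these data alone, it is also open whether acetyl gives the same rise on compound 2.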